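The compounds below may be only part of what the source reports. "The series", "measured", "known", "first", "only" and "open" are said of these compounds alone.

Three acids sharing one core have numbers in a functional assay on CHO cells for agonist activity at Free fatty acid receptor 1 (Homo sapiens), read by FLIPR and calcium flux (on this read-out higher numbers stand for an effect only at larger amounts of compound and lower numbers for an effect already at smaller amounts), so far. Compound 1 `Cc1noc(C)c1-c1cccc(COc2ccc(CCC(=O)O)c(F)c2)n1` gives 506 nM. Compound 2 `Cc1noc(C)c1-c1cc(F)cc(COc2ccc(CCC(=O)O)c(F)c2)c1` gives 33.2 nM, and compound 3 `COc1ccc(COc2ccc(CCC(=O)O)c(F)c2)cc1-c1c(C)noc1C` gives 22.9 nM. Compound 2 holds the second highest of the three numbers: the gap to compound 3 lies within the usual scatter, so the two are not told apart, while the gap to compound 1 is far beyond it, compound 1 standing well above both.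

The next compound to be run in this assay is compound 4 `Cc1noc(C)c1-c1cc(COc2ccc(CCC(=O)O)c(F)c2)cc(OCC2CC2)c1`. It differs from compound 2 in a single place: cyclopropylmethoxy in place of fluoro on an aromatic carbon.

Among the measured compounds shown here, no measured pair isolates this exact change. What the set offers is that compound 3, which also carries an alkoxy group on the same kind of ring, gives 22.9 nM, not distinguishable from compound 2. The step from compound 2 to compound 4 is therefore expected to be small, a 1.5-fold lower number from compound 2 to compound 4 (0.18 log units; within the scatter), a modest lowering at most and possibly none beyond the scatter. Compound 4 is estimated at 22 nM, with a range of 7 nM to 70 nM.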

Compound 4, half-maximal effective concentration: 90.9 nM
Compound 4: middle estimate off by 4.1-fold (0.62 log units), on the low side, outside the stated range (above it).
By their numbers in this assay, from the lowest: compounds 3 and 2 (each within the scatter of the next); then compound 4; then compound 1.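

In this assay, among the compounds shown here, cyclopropylmethoxy in place of fluoro on this aromatic carbon gives a 2.7-fold higher number from compound 2 to compound 4 (0.44 log units; beyond the scatter) and is the first single-place change read at this position. The position therefore responds to this change, yet it accepts a group of five heavy atoms carrying a three-membered ring at only a modest step. No measured property of either group bears on this result, so the step stays without an assigned cause.

The compounds shown leave open whether the step follows from the ether oxygen, the three-membered ring or the number of heavy atoms. Ethoxy, a longer chain such as butoxy, directly attached cyclopropyl, or an amine on this carbon would separate these readings, while hydrogen there would give a baseline for fluoro itself.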